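The source may report more compounds than this note shows. Statements on the series, on what has been measured and on what is new or still open speak of the compounds shown alone.

Going by the values given here, compound 2, `COc1cc(OC)c(/C=C/S(=O)(=O)Cc2ccc(C(=O)O)cc2)c(OC)c1`, is the weaker of the two compounds measured so far in a functional assay on DU-145 cells (Homo sapiens) for antiproliferative activity, read by trypan blue exclusion; a lower number here means a stronger inhibitor, a higher number a weaker inhibitor: compound 2 gives 10000 nM, the highest number of the pair. The other measured compound, compound 1, `COc1cc(OC)c(/C=C/S(=O)(=O)Cc2ccc(OC)c(OP(=O)(O)O)c2)c(OC)c1`, carries a methoxy and a phosphate on its benzyl ring instead of the carboxy, and in this assay compound 1 gives 2.5 nM, a far lower number that lies well beyond the usual scatter.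

Compound 3, `COc1ccc(CS(=O)(=O)/C=C/c2c(OC)cc(OC)cc2OC)cc1`, is not yet measured. It differs from compound 2 in one place: methoxy in place of carboxy on an aromatic carbon. Nothing more than this single exchange separates the two structures.

Since compound 1, which also bears a methoxy at that position of the benzyl ring, gives 2.5 nM, the number for compound 3 is expected to fall considerably from that of compound 2, a step estimated as a 100-fold lower number from compound 2 to compound 3 (2.00 log units; beyond the scatter), toward stronger inhibition, though compound 3 lacks the phosphate of compound 1 and need not reach that level. Compound 3 is estimated at 100 nM, with a likely range from 10 nM to 2000 nM.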

Compound 3, half-maximal inhibitory concentration: 25 nM
Compound 3: the middle estimate sits 4.0-fold (0.60 log units) above what was measured, and the stated range covers the measured number.
By their numbers in this assay, from the lowest: compound 1; then compound 3; then compound 2.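

In this assay the exchange of carboxy for methoxy on an aromatic carbon, para to a large group, gives a 400-fold lower number from compound 2 to compound 3 (2.60 log units; beyond the scatter) and is a large step, so this position of the shared core clearly distinguishes between these two groups. The 4-methoxyphenyl group alone, however, does not bring the number down to that of compound 1: with a hydrogen atom in place of the phosphate, the change gives a 10-fold higher number from compound 1 to compound 3 (1.00 log units; beyond the scatter) and is a modest step, still beyond the scatter, and much smaller than the step between carboxy and methoxy. No evidence at hand accounts for the size of either step.

The compounds shown leave open how an amine, a hydroxy or an ethoxy would read in place of the methoxy, and so whether the large step reflects the loss of the carboxy, the arrival of the methoxy, or both. They also leave open whether a hydroxy in place of the phosphate of compound 1 would give a number closer to that of compound 1 or to that of compound 3.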